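This account rests on a few compounds, and the source may have more. Where it says the series, first, only, none or still open, it means among the compounds named here.

Compound 1, `CC(C)(C)C[N+]1(C)CCc2c(sc(NC(=O)Nc3ccc(Cl)cc3)c2C(N)=O)C1`, is one of three compounds tested in a functional assay (strain AB) with Danio rerio as the target, read by microscopy, with a stated time of 1 h; on this read-out lower numbers stand for an effect already at smaller amounts and higher numbers for an effect only at larger amounts of compound. In this assay compound 1 gives 290 nM, the lowest of the three numbers. Compound 3, `NC(=O)c1c(NC(=O)Nc2ccc(Cl)cc2)sc2c1CCN(CCCNC(=O)CCc1cccnc1)C2`, gives 470 nM in this assay, a value that lies within the usual scatter of compound 1. Compound 2, `CC(C)(C)CN1CCc2c(sc(NC(=O)Nc3ccc(Cl)cc3)c2C(N)=O)C1`, gives 5560 nM in this assay, a value that lies well beyond the scatter from compound 1. No pair among these three differs in a single place, so no single step has been measured.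

Compound 4, `CC(C)(C)OC(=O)CCCC[N+]1(C)CCc2c(sc(NC(=O)Nc3ccc(Cl)cc3)c2C(N)=O)C1`, has not yet been measured in this assay. It differs from compound 1 in one place: 3-(tert-butoxycarbonyl)propyl in place of tert-butyl on a saturated chain carbon bound to an amine nitrogen in a ring. Nothing in the measured compounds tells directly how this change will read, so the expectation rests only on the values of compound 1 and compound 3. The step in this assay from compound 1 to compound 4 is expected to be a 1.6-fold higher number from compound 1 to compound 4 (0.19 log units; within the scatter), with no clear direction beyond the scatter. Compound 4 is therefore estimated to give 450 nM in this assay, within a range from 120 nM to 1700 nM.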

Compound 4, half-maximal effective concentration: 140 nM
Compound 4: middle estimate off by 3.2-fold (0.51 log units), on the high side; the measured number falls inside the stated range.
By their numbers in this assay, from the lowest: compound 4; then compounds 1 and 3 (each within the scatter of the next); then compound 2.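

In this assay, within the data shown here, the change from tert-butyl to 3-(tert-butoxycarbonyl)propyl gives a 2.1-fold lower number from compound 1 to compound 4 (0.32 log units; beyond the scatter) and is the first single change measured at this place, on a saturated chain carbon bound to an amine nitrogen in a ring. The step is modest, but it shows that a group of 10 heavy atoms with 2 hydrogen-bond acceptors can replace one of 4 heavy atoms with none, and the number does not rise. Nothing measured here accounts for this step.

The compounds shown leave open whether the lower number comes from the longer chain itself or from its tert-butoxycarbonyl end. A plain alkyl chain of similar length, a free carboxylic acid or an amine at the chain end would help separate these two possibilities.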